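A few compounds are considered here, and "the series" means these few. Any claim that something is new, unique, unknown or untested is made for them only; others in the source may bear on it.

Measured so far:
- compound 1, `CC(C)OC(=O)C1=C(C(F)(F)F)NC(=O)NC1c1ccsc1`: in an assay on HeLa cells for displacement of a labelled ligand from adenosine receptor A3 (Homo sapiens), read by radioligand binding, with a stated time of 180 min, tested at 1 uM (on this read-out lower numbers stand for less inhibition and higher numbers for more inhibition at the one concentration tested (going by the name of the read-out)), compound 1 gives 3%
- compound 2, `CCOC(=O)C1=C(C(F)(F)F)NC(=O)NC1c1ccsc1`: compound 2 gives 3%
- compound 3, `CC1=C(C(=O)OC(C)C(F)(F)F)C(c2ccco2)NC(=O)N1`: compound 3 gives 11%; 7% (2 entries)

All three measured compounds show little inhibition at the single concentration tested. Compound 1 stands level with compound 2, its nearest neighbour: the step of no change at the digits printed from compound 1 to compound 2 (within the scatter) shows that swapping the isopropyl ester for an ethyl ester leaves the read-out unchanged. Compound 3, which carries a furan-2-yl group on the shared core, was measured more than once, and its repeated entries the several entries of compound 3 in this assay, 11%; 7% (2 entries) show how much two measurements of the same compound can differ.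

The unmeasured compound 4, `CC(C)OC(=O)C1=C(C(F)(F)F)NC(=O)NC1c1ccco1`, differs from compound 1 in one place: furan-2-yl in place of thiophen-3-yl on a saturated ring carbon. Among the compounds with values here, no measured pair differs by exactly this change, so no step bears on it directly. Within the data shown here, compound 3 is the only measured compound with a furan-2-yl group, and it differs from compound 1 in other places as well, so its value can only be taken as a hint that a furan-2-yl compound of this series also sits at a low level. Taken together, no step beyond the scatter is expected, and the expected step is a number 2 percentage points higher from compound 1 to compound 4 (within the scatter). Compound 4 is therefore estimated at 5%, within a range of -5% to 15%.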

Compound 4, a percentage reported as inhibition, at one concentration (the size of the read-out at that concentration, not a potency): 5%
The estimate for compound 4 equals the measured number at the digits printed, within the range that was stated.
By their numbers in this assay, from the lowest: compounds 1, 2 and 4 (each within the scatter of the next).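

In this assay, within the data shown here, this is the first direct look at the saturated ring carbon that carries the five-membered aromatic ring, with the rest of the molecule held fixed: furan-2-yl in place of thiophen-3-yl gives a number 2 percentage points higher from compound 1 to compound 4 (within the scatter). The two groups have the same heavy-atom count and differ in the ring hetero atom, oxygen against sulfur, and in the ring atom through which they attach, yet these differences leave the read-out in the same low band. The step is no larger than the gap between two entries for a single compound, so it cannot be told apart from repeat variation: the several entries of compound 3 in this assay, 11%; 7% (2 entries)

Going by these compounds, both groups at this position are five-membered aromatic rings with one hetero atom, so it remains open whether a phenyl ring, an aminomethyl group or a carboxylic acid in the same place would give more inhibition on the shared core. Also open, on these data alone, is whether a longer chain on the ester, such as a butyl group, would move the read-out when combined with either ring.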